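The source may hold more compounds than are shown below. What is called first, only, known or untested is meant among the compounds shown, and "the series" means these compounds.

Working notes on the nitrocatechol chalcone series.

Of the compounds shown here, three have been measured in an assay for inhibition of Catechol O-methyltransferase (Rattus norvegicus), read by fluorescence and spectrophotometry; on this read-out lower numbers stand for stronger inhibition and higher numbers for weaker inhibition. Compound 1 `N#Cc1cccc(/C=C/C(=O)c2cc(O)c(O)c([N+](=O)[O-])c2)c1` gives 240 nM in this assay. Compound 2 `O=C(/C=C/c1cccs1)c1cc(O)c(O)c([N+](=O)[O-])c1` gives 190 nM in this assay. Compound 3 `O=C(/C=C/c1cccc(O)c1)c1cc(O)c(O)c([N+](=O)[O-])c1` gives 140 nM in this assay, the lowest of the three numbers, though its steps to the others stay within the scatter: a 1.7-fold lower number from compound 1 to compound 3 (0.23 log units; within the scatter) and a 1.4-fold lower number from compound 2 to compound 3 (0.13 log units; within the scatter). The three numbers therefore sit within one band, and none of the compounds can be called stronger than another.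

The next compound, compound 4 `O=C(/C=C/c1ccco1)c1cc(O)c(O)c([N+](=O)[O-])c1`, differs from compound 3 in one place: furan-2-yl in place of 3-hydroxyphenyl on a double-bonded chain carbon bound to a double-bonded chain carbon. Among the compounds with values here, the step that bears most on this change is the one from compound 2 to compound 3, which swapped a five-membered aromatic ring with one hetero atom for the 3-hydroxyphenyl group and gave a 1.4-fold lower number from compound 2 to compound 3 (0.13 log units; within the scatter). Reversing that sort of exchange, now with furan-2-yl entering, is expected to give a step of similar size in the opposite sense, a 1.6-fold higher number from compound 3 to compound 4 (0.20 log units; within the scatter), which remains within the scatter. Compound 4 is therefore estimated at 220 nM in this assay, with a range from 100 nM to 500 nM.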

Compound 4, half-maximal inhibitory concentration: 230 nM
For compound 4 the middle estimate is 1.0-fold (0.02 log units) below the measured one, within the range that was stated.
By their numbers in this assay, from the lowest: compounds 3, 2, 4 and 1 (each within the scatter of the next).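

With furan-2-yl in place of 3-hydroxyphenyl on a double-bonded chain carbon bound to a double-bonded chain carbon, this assay gives a 1.6-fold higher number from compound 3 to compound 4 (0.22 log units; within the scatter), so this exchange of a six-membered aromatic ring of carbon only, carrying a hydrogen-bond donor, for a five-membered aromatic ring with a hetero atom and no donor stays inside the band already seen. Within the data shown here, the new pair of five-membered rings adds a comparison the earlier compounds could not offer: a 1.2-fold higher number from compound 2 to compound 4 (0.08 log units; within the scatter), which leaves furan-2-yl and thiophen-2-yl indistinguishable at this place. No other measurement bears on this result.

Open, on these data alone, is whether any group at this place gives a step beyond the scatter, for instance a saturated ring such as cyclohexyl, or a ring carrying an amine or a carboxylic acid. Plain phenyl at this place would be the direct test of whether the hydroxy of 3-hydroxyphenyl counts for anything in this assay.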